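This account rests on a few compounds, and the source may have more. Where it says the series, first, only, none or still open, it means among the compounds named here.

Working notes on the series in a functional assay on MCF7 cells (Homo sapiens) for antiproliferative activity, read by sulforhodamine B assay, with a stated time of 3 days; a lower number here means a stronger inhibitor, a higher number a weaker inhibitor.

Compound 1, `c1ccc(Sc2ncnc3[nH]cnc23)cc1`, gives 31000 nM in this assay. Compound 2, `Fc1ccc(Sc2ncnc3[nH]cnc23)cc1`, carries the change fluoro in place of hydrogen on an aromatic carbon relative to compound 1, and in this assay compound 2 gives 31600 nM. The step of a 1.0-fold higher number from compound 1 to compound 2 (0.01 log units; within the scatter) is within the scatter, so the two numbers cannot be ordered.

Compound 3, `c1ccc(Sc2ncnc3ncn(C4COc5ccccc5CO4)c23)cc1`, has a different core from compound 1; the difference between the two cores is not broken down here. In this assay, going by the values given here, compound 3 gives 15600 nM, the lowest of the three numbers so far, though its gap to compound 1 is within the scatter and only its gap to compound 2 lies beyond it.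

Compound 4, `Fc1ccc(Sc2ncnc3ncn(C4COc5ccccc5CO4)c23)cc1`, is not yet measured. It stands to compound 3 as compound 2 stands to compound 1: the change (fluoro in place of hydrogen on an aromatic carbon), the same change with the same surroundings of the place in both pairs. Among the compounds shown this change occurs twice in all, and the one measured instance is the step from compound 1 to compound 2 given above.

The expectation for compound 4 rests on that single precedent: since the step of a 1.0-fold higher number from compound 1 to compound 2 (0.01 log units; within the scatter) sits within the scatter, the step of a 1.0-fold higher number from compound 3 to compound 4 (0.01 log units; within the scatter) is expected to be about as small. Among the compounds with values here, compound 4 is accordingly estimated at 16000 nM in this assay, with a range from 7000 nM to 35000 nM to allow for the scatter of a single measurement and for the fact that only one example of the change has been measured.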

Compound 4, half-maximal inhibitory concentration: 14100 nM
Beside the measured number, compound 4's estimate is 1.1-fold (0.05 log units) above it; the measured number falls inside the stated range.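

In this assay the fluoro change gives a 1.1-fold lower number from compound 3 to compound 4 (0.04 log units; within the scatter) and the pair therefore cannot be ordered. Set beside the earlier step, the same change on the two cores shows no difference that can be told from the scatter: the same change on two cores in this assay, a 1.0-fold higher number (0.01 log units; within the scatter) from compound 1 to compound 2 and a 1.1-fold lower number (0.04 log units; within the scatter) from compound 3 to compound 4, 1.1-fold (0.05 log units) apart, within the scatter of two such steps. This shows that, on these two cores, fluoro in place of hydrogen on an aromatic carbon, para to a large group, leaves the number within the scatter both times; it does not show that the change would behave in the same way on any other core or in any other assay, and since neither step rises out of the scatter, the agreement is between two unresolved steps, not between two measured effects of the same size.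

The compounds shown leave open whether a group other than fluoro at this place, such as chloro, methoxy, an amine or a carboxylic acid, would move the number beyond the scatter. Also open, on these data alone, is how the number responds on either core when the whole phenylsulfanyl group gives way to a different group, such as an amine or a longer chain.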